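A few compounds are considered here, and "the series" means these few. Any claim that something is new, unique, unknown or untested is made for them only; others in the source may bear on it.

Three compounds of the series share one core, an acetyl-hydroxyphenyl ether joined through a long chain to a basic amine. Compound 1 `CC(=O)c1ccc(OCCCCCCCCCN2CCc3ccccc3C2)cc1O` gives 19400 nM in an assay on isolated protein for inhibition of Amine oxidase [flavin-containing] B (Homo sapiens), read by fluorescence, with a stated time of 30 min; a lower number here means a stronger inhibitor, a higher number a weaker inhibitor. Compound 2 `CCN(CCCCCCCCCCOc1ccc(C(C)=O)c(O)c1)Cc1ccccc1` gives 23400 nM in this assay. Compound 3 `CC(=O)c1ccc(OCCCCCCCCCCN2CCC(c3ccccc3)CC2)cc1O` gives 14200 nM in this assay, the lowest number of the three, though its gaps to compound 1 and to compound 2 both lie within the scatter, so no order among them can be read. Compound 4 `CC(=O)c1ccc(OCCCCCCCCCCN2CCC(Cc3ccccc3)CC2)cc1O` is not yet measured; it differs from compound 3 by benzyl in place of phenyl on a saturated ring carbon. For the measured compounds named here, no measured pair shows such a change, so a step of no more than the scatter is expected, in either direction. Compound 4 is expected at 12000 nM in this assay, within 5000 nM to 30000 nM, a step of a 1.2-fold lower number from compound 3 to compound 4 (0.07 log units; within the scatter).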

Compound 4, half-maximal inhibitory concentration: 21600 nM
The estimate for compound 4 lay 1.8-fold (0.26 log units) below the measured number; the range from low to high includes it.
By their numbers in this assay, from the lowest: compounds 3, 1, 4 and 2 (each within the scatter of the next).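

Benzyl in place of phenyl on a saturated ring carbon, three ring bonds from the ring nitrogen, brings a 1.5-fold higher number from compound 3 to compound 4 (0.18 log units; within the scatter) in this assay, the only pair shown that tests this position. At this position, the change from phenyl to benzyl therefore leaves the number within the scatter, and no direction can be read. Nothing at hand explains the result. As far as these compounds go, whether an amine, a carboxylic acid or a longer chain at this ring carbon would carry the number beyond the scatter remains open.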